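The compounds below may be only part of what the source reports. "The series", "measured", "known", "first", "only" and "open" are said of these compounds alone.

Measured in an ADME assay on PBMC cells (Homo sapiens) for cytotoxicity, read by MTT assay, with a stated time of 24 h; on this read-out lower numbers stand for stronger inhibition and higher numbers for weaker inhibition:
- compound 1 `COc1cc(C)cc2c1C(=O)C=C(c1c(C)cc3c(c1OC)C(=O)C(Nc1ccc(Cl)cc1)=CC3=O)C2=O`: 44900 nM
- compound 2 `COc1cc(C)cc2c1C(=O)C=C(c1c(C)cc3c(c1OC)C(=O)C(N)=CC3=O)C2=O`: > 100000 nM (a limit)

Compound 2 stands at > 100000 nM, which is a limit and not a number. This is the limit of > 100000 nM in this assay, at which 1 of the 2 values shown sits.

Compound 3 `COc1cc(C)cc2c1C(=O)C(N)=C(c1c(C)cc3c(c1OC)C(=O)C(N)=CC3=O)C2=O` is still to be measured. It differs from compound 2 by amino in place of hydrogen on a double-bonded ring carbon of a six-membered non-aromatic ring of carbon only, next to the ring atom that bears a large group.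

Among the measured compounds shown here, the only measured step is an at least 2.2-fold higher number from compound 1 to compound 2 (0.34 log units; beyond the scatter). For the measured compounds named here, that step is hydrogen in place of 4-chlorophenyl on an amine nitrogen, so it bears on the new amino group only indirectly, and no measured step covers this change itself. Its size is also only a lower bound. With that step pointing toward weaker inhibition, compound 3 is expected to stay close to the limit in this assay, and a limit reading is quite possible.

The expected change is small, estimated as a number no higher from compound 2 to compound 3 (the limit leaves the size open).

For compound 3 the estimated value is 100000 nM, with an expected range of 40000 nM to 250000 nM.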

Compound 3, half-maximal inhibitory concentration: 40600 nM
Estimate against measurement, compound 3: 2.5-fold (0.39 log units) above; measured number inside the range.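

Working notes: in this assay, the double-bonded ring carbon next to the ring atom that bears a large group proves responsive, with amino in place of hydrogen giving an at least 2.4-fold lower number from compound 2 to compound 3 (0.39 log units; beyond the scatter). Among the compounds shown here, the only earlier step concerned a different site, the amine nitrogen, and read an at least 2.2-fold higher number from compound 1 to compound 2 (0.34 log units; beyond the scatter), so the series now has a second position where a single change moves the read-out beyond the scatter, and here a simple amino group is enough to do so. The reading for compound 2 is a limit and not a number, so the new step gives only a lower bound on the size of the change: the limit of > 100000 nM in this assay, at which 1 of the 3 values shown sits.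

From the compounds shown here alone, whether the shift belongs to amino itself stays open, since a hydroxyl, a methoxy or a methylamino group on the same carbon would be needed to separate it from other small substituents, and a 4-chlorophenyl on the new amino nitrogen would show whether the two sites add up. The compounds shown also offer no measured property that could account for the step, so its cause remains unassigned.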